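Pyridin-2-yl in Place of 2-Fluorophenyl

The compounds below may be only part of what the source reports. "The series", "measured", "known", "first", "only" and "open" are said of these compounds alone.

In an ADME assay (liver) for metabolic stability, with Liver microsome (Homo sapiens) as the target, using microsomes (on this read-out higher numbers stand for fast clearance and lower numbers for slow clearance), compound 1 (`O=c1[nH]c2ccc(-c3nnc(NCc4ccccc4)o3)cc2o1`) gives 69 mL.min-1.g-1 and compound 2 (`Fc1ccccc1CNc1nnc(-c2c[nH]c3ncccc23)o1`) gives 32 mL.min-1.g-1 as its reading. Compound 2 thus holds the lower of the two numbers, and its gap to compound 1 lies beyond the usual scatter of repeated measurements. These two compounds differ in more than one place, so their gap cannot be tied to any single change.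

Compound 3 (`c1ccc(CNc2nnc(-c3c[nH]c4ncccc34)o2)nc1`) differs from compound 2 in one place, with pyridin-2-yl in place of 2-fluorophenyl on a saturated chain carbon bound to a nitrogen on an aromatic ring. Among the compounds with values here, no measured pair shows what this swap does, so any forecast is rough. A small fall in this assay is expected, probably within the scatter (estimated step a 1.6-fold lower number from compound 2 to compound 3 (0.20 log units; within the scatter)). For compound 3 the estimated value is 20 mL.min-1.g-1 (expected range 9 mL.min-1.g-1 to 40 mL.min-1.g-1).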

Compound 3, intrinsic clearance in microsomes: < 14 mL.min-1.g-1
Compound 3 was reported as a limit; the forecaster's own chance of this, stated with the estimate: 3%; middle value at least 1.4-fold (0.15 log units) from the limit.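

In this assay, within the data shown here, pyridin-2-yl in place of 2-fluorophenyl gives an at least 2.2-fold lower number from compound 2 to compound 3 (0.35 log units; beyond the scatter), so this position clearly bears on the read-out, which the first pair of compounds, differing in more than one place, could not show. The reading of compound 3 is a limit of the assay and not a number, so the step gives only its smallest size: the limit of < 14 mL.min-1.g-1 in this assay, at which 1 of the 3 values shown sits.

The swap exchanges a carbon-only ring carrying fluorine for a ring with one hetero atom and one hydrogen-bond acceptor, and this single pair cannot separate those differences.

From the compounds shown here alone, it remains open whether a pyridin-3-yl or pyrimidin-2-yl group in the same place would give a similar reading, which would show how much depends on the ring nitrogen. Also open, going by these compounds, is whether the same swap would give a similar step on the core of compound 1.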